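Swapping the benzyl-side substituent on an oxime ether

The compounds below may be only part of what the source reports. "The series", "measured", "known", "first", "only" and "open" are said of these compounds alone.

Of the compounds shown here, three sharing one core have been tested in an assay on HepG2 cells for agonist activity at nuclear receptor subfamily 1 group I member 3 (Homo sapiens), read by a luciferase reporter, with a stated time of 23 h; a higher number here means that more compound is needed for the effect, a lower number that less compound is needed. Compound 1 `Clc1ccc(CO/N=C/c2c(-c3ccc4ccccc4c3)nc3occn23)cc1Cl` gives 370 nM. Compound 2 `C(=N/OCc1ccccc1)\c1c(-c2ccc3ccccc3c2)nc2occn12` gives 840 nM. Compound 3 `FC(F)(F)c1ccc(CO/N=C/c2c(-c3ccc4ccccc4c3)nc3occn23)cc1` gives 470 nM, which places compound 3 second of the three numbers, within the scatter of both neighbours. The measured steps were a 2.3-fold higher number from compound 1 to compound 2 (0.36 log units; beyond the scatter), a 1.3-fold higher number from compound 1 to compound 3 (0.10 log units; within the scatter) and a 1.8-fold lower number from compound 2 to compound 3 (0.25 log units; within the scatter): only the removal of both chlorines reached beyond the scatter, and the exchange between the two halogenated groups did not.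

Compound 4 `Clc1ccccc1CO/N=C/c1c(-c2ccc3ccccc3c2)nc2occn12` is the next case: 2-chlorophenyl in place of 4-(trifluoromethyl)phenyl on a saturated chain carbon bound to an oxygen on an unsaturated carbon. Among the compounds with values here, the change again trades one halogenated phenyl for another, and the nearest comparison, compound 1 to compound 3, gave a step within the scatter, while the unsubstituted phenyl of compound 2 gave the only larger number. A small step is therefore expected for compound 4 in this assay, and with one chlorine rather than two or a trifluoromethyl the estimate leans slightly toward a higher number, a 1.3-fold higher number from compound 3 to compound 4 (0.11 log units; within the scatter). The expected value for compound 4 is 600 nM, with a range from 250 nM to 1400 nM.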

Compound 4, half-maximal effective concentration: 1100 nM
Compound 4: middle estimate off by 1.8-fold (0.26 log units), on the low side; the range from low to high includes it.
By their numbers in this assay, from the lowest: compounds 1, 3, 2 and 4 (each within the scatter of the next, the first and the last beyond it).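

A halogen on this phenyl does not by itself keep the number low: there is a 1.3-fold higher number from compound 2 to compound 4 (0.12 log units; within the scatter) on adding the chloro group, so compound 4 sits with the unsubstituted phenyl of compound 2 and not with the other halogenated groups. Those groups stand apart from 2-chlorophenyl by a 2.3-fold higher number from compound 3 to compound 4 (0.37 log units; beyond the scatter) and by a 3.0-fold higher number from compound 1 to compound 4 (0.47 log units; beyond the scatter) at this same place, so the earlier small step between compound 1 and compound 3 does not extend to every halogenated phenyl. No measurement at hand explains this difference.

Compound 4 differs from compound 1 in both the number and the placing of its chlorines, and these two changes cannot be separated here. Going by these compounds, how this place responds to a group of another kind, such as an amine or a carboxylic acid on the phenyl, also stays open.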